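One Exchanged Group Between Compound 2 and Compound 3

The compounds below may be only part of what the source reports. "The series", "measured", "known", "first", "only" and "open" are said of these compounds alone.

Compound 1 `CCCCc1ccc(CNS(C)(=O)=O)c(=O)n1Cc1ccc(-c2ccccc2-c2nn[nH]n2)cc1` and compound 2 `CCCCc1ccc(CN(C)S(=O)(=O)c2ccccc2)c(=O)n1Cc1ccc(-c2ccccc2-c2nn[nH]n2)cc1` share one core and differ only in the group on a saturated chain carbon bound to an aromatic carbon. In a functional assay on the whole organism (artery) for inhibition, with Rattus norvegicus as the target, at a dose of 3 mg/kg by the intraduodenal route (a higher number here means more inhibition at the dose given (going by the name of the read-out), a lower number less inhibition), compound 1 gives 54.8%, while compound 2 gives 68.7%, a step described as a number 13.9 percentage points higher from compound 1 to compound 2 (beyond the scatter). Among the two numbers known so far, compound 2 stands highest, with compound 1 as its only neighbour.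

Compound 3 `CCCCc1ccc(CNC(=O)Nc2ccccc2)c(=O)n1Cc1ccc(-c2ccccc2-c2nn[nH]n2)cc1` has not yet been tested. It differs from compound 2 by (phenylcarbamoyl)amino in place of methyl(phenylsulfonyl)amino on a saturated chain carbon bound to an aromatic carbon. Within the data shown here, the one measured step changed the same position and was modest, but it exchanged other groups, so it only shows that a change at this position gave a number that was higher without a large swing. Compound 3 is therefore expected to move by a number 13.7 percentage points lower from compound 2 to compound 3 (beyond the scatter) in this assay, and its value is estimated at 55%, between 30% and 78%.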

Compound 3, a percentage reported as inhibition, in the whole organism at one dose (the size of the read-out at that dose, not a potency): 0%
Beside the measured number, compound 3's estimate is 55 percentage points above it; measured number below the stated range.
By their numbers in this assay, from the lowest: compound 3; then compound 1; then compound 2.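

In this assay, the group on a saturated chain carbon bound to an aromatic carbon can do far more than shift the number modestly: (phenylcarbamoyl)amino brings a number 68.7 percentage points lower from compound 2 to compound 3 (beyond the scatter) and, with phenylcarbamoyl in place of methylsulfonyl on an amine nitrogen, a number 54.8 percentage points lower from compound 1 to compound 3 (beyond the scatter) in the same read-out. Among these three compounds, both sulfonyl-bearing groups go with clear inhibition at this dose, while the phenylcarbamoyl group goes with none, although the exchange alters several features at once. Nothing available here explains this loss.

The compounds shown leave open whether the loss follows from the carbonyl in place of the sulfonyl or from the added nitrogen hydrogen. An acetyl group or a benzoyl group on the same amine nitrogen would help separate these two possibilities.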